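A few compounds are considered here, and "the series" means these few. Any claim that something is new, unique, unknown or untested is made for them only; others in the source may bear on it.

Measured compounds:
Compound 1, `COc1cc(/C=C2\CCC/C(=C\c3ccccc3[N+](=O)[O-])C2=O)cc(Br)c1OC`, gives 3.35 ug/mL in a functional assay on MCF7 cells (Homo sapiens) for cytotoxicity, read by MTT assay; a higher number here means a weaker inhibitor, a lower number a stronger inhibitor.
Compound 2, `COc1cc(/C=C2\CCC/C(=C\c3cccc([N+](=O)[O-])c3)C2=O)cc(Br)c1OC`, gives 4.72 ug/mL in this assay.
Compound 3, `COc1cc(/C=C2\CCC/C(=C\c3ccc([N+](=O)[O-])cc3)C2=O)cc(Br)c1O`, gives 4.93 ug/mL in this assay.

These three share one core and differ only in two places: where the nitro group sits on the phenyl ring, and whether the oxygen on the other aromatic ring carries a methyl. Among the measured compounds shown here, the single step that can be read directly, a 1.4-fold higher number from compound 1 to compound 2 (0.15 log units; within the scatter), moves the nitro group and stays within the scatter. Compound 3 sits alongside the other two: its number lies within the scatter of both compound 2 and compound 1, so none of the three can be told apart on these numbers.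

Compound 4, `COc1cc(/C=C2\CCC/C(=C\c3ccc([N+](=O)[O-])cc3)C2=O)cc(Br)c1OC`, is the next compound. It differs from compound 3 by methyl in place of hydrogen on an oxygen on an aromatic ring. For the measured compounds named here, no measured pair here changes this oxygen; the only measured step concerns the nitro position and was small. There is therefore nothing in these data pointing to a shift in either direction for this assay, and no step beyond the scatter is expected: a 1.1-fold lower number from compound 3 to compound 4 (0.04 log units; within the scatter) is the expected step. The estimate for compound 4 in this assay is 4.5 ug/mL, with a range from 2.2 ug/mL to 9 ug/mL.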

Compound 4, half-maximal inhibitory concentration: 11 ug/mL
For compound 4 the middle estimate is 2.4-fold (0.39 log units) below the measured one; measured number outside the range, above it.
By their numbers in this assay, from the lowest: compounds 1, 2 and 3 (each within the scatter of the next); then compound 4.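

Among the compounds shown here, on the oxygen on an aromatic ring, the change from hydroxy to methoxy is the first single change here to pass the scatter in this assay: the data show a 2.2-fold higher number from compound 3 to compound 4 (0.35 log units; beyond the scatter) and, since a higher number means a weaker inhibitor, adding this methyl weakens compound 4 relative to compound 3. With methyl on that oxygen in all three compounds compared, the nitro position also matters: 4-nitrophenyl in place of 3-nitrophenyl gives a 2.3-fold higher number from compound 2 to compound 4 (0.37 log units; beyond the scatter) and 4-nitrophenyl in place of 2-nitrophenyl gives a 3.3-fold higher number from compound 1 to compound 4 (0.52 log units; beyond the scatter), while the earlier step between the other two nitro positions stayed within the scatter. Nothing measured here accounts for why either change moves the number.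

On these data alone, whether hydroxy and methoxy would differ in the same way with the nitro group on the other two positions remains open, so the size of this step may belong to the 4-nitrophenyl compounds alone. As far as these compounds go, how this oxygen would respond to a longer chain such as ethyl, or the phenyl ring to an amine or a carboxylic acid in place of the nitro group, also remains open.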